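Cathepsin S series: cyclopentenyl to tert-butyl at the side chain

A few compounds are considered here, and "the series" means these few. Any claim that something is new, unique, unknown or untested is made for them only; others in the source may bear on it.

Measured so far:
compound 1, `C[C@@H]1CC[C@H](NC(=O)[C@H](CCC2CCCC2)NC(=O)N2CCOCC2)C(=O)CN1S(=O)(=O)c1ccccn1`: 0.58 nM
compound 2, `C[C@@H]1CC[C@H](NC(=O)[C@H](CC2=CCCC2)NC(=O)c2ccco2)C(=O)CN1S(=O)(=O)c1ccccn1`: 4.9 nM

Both numbers come from an assay on isolated protein for inhibition of cathepsin S (Homo sapiens), read by fluorescence; on this read-out lower numbers stand for stronger inhibition and higher numbers for weaker inhibition. Within the data shown here, of the two, compound 2 stands at the higher number; compound 1 sits well beyond the scatter from it, but the two differ in more than one place, so no single step is drawn between them.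

Compound 3, `C[C@@H]1CC[C@H](NC(=O)[C@H](CC(C)(C)C)NC(=O)c2ccco2)C(=O)CN1S(=O)(=O)c1ccccn1`, is the next member. It differs from compound 2 in one place: tert-butyl in place of cyclopent-1-en-1-yl on a saturated chain carbon, two bonds along the chain from an amide-type nitrogen and a carbonyl carbon. No measured pair isolates such a change, so any expectation rests on the general tolerance the series has shown at this position.

In this assay the step from compound 2 to compound 3 is estimated at a 2.0-fold higher number from compound 2 to compound 3 (0.31 log units; beyond the scatter), a modest move toward weaker inhibition, near the edge of the usual scatter. Compound 3 is accordingly expected to give 10 nM, within a range of 3 nM to 40 nM.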

Compound 3, half-maximal inhibitory concentration: 1.3 nM
Beside the measured number, compound 3's estimate is 7.7-fold (0.89 log units) above it; the measured number lies below the stated range.
By their numbers in this assay, from the lowest: compound 1; then compound 3; then compound 2.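

In this assay, among these compounds, tert-butyl in place of cyclopent-1-en-1-yl gives a 3.8-fold lower number from compound 2 to compound 3 (0.58 log units; beyond the scatter) and provides the first single-place step at this site, on a saturated chain carbon, two bonds along the chain from an amide-type nitrogen and a carbonyl carbon. With the rest of compound 2 held fixed, neither the ring nor the double bond outside aromatic rings is required for strong inhibition here, and the open-chain group with one heavy atom fewer is the better of the two. Nothing at hand bears on the origin of this step.

Going by these compounds, this rests on a single pair, and compound 1 differs from both in more than one place, so it stays open whether the step carries over to other parts of the series. Also open, on these data alone, is how isopropyl, phenyl or an amine would fare at this site.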